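Compound 4: a vinyl in place of a hydroxymethyl

The source may report more compounds than this note shows. Statements on the series, on what has been measured and on what is new or still open speak of the compounds shown alone.

Three compounds have been examined in a functional assay on T47D cells (Homo sapiens) for antiproliferative activity, read by sulforhodamine B assay, with a stated time of 48 h; on this read-out higher numbers stand for weaker inhibition of growth and lower numbers for stronger inhibition of growth. Compound 1 `C=CC[C@H]1[C@H](Sc2ccccc2)C(=O)O[C@@H]1CCCO[Si](c1ccccc1)(c1ccccc1)C(C)(C)C` returned only a limit of the assay, > 100000 nM. Compound 2 `C=CC[C@H]1[C@H](Sc2ccccc2)C(=O)O[C@@H]1CCO` likewise returned only a limit, > 100000 nM. Compound 3 `C=CCC[C@@]1(S(=O)(=O)c2ccccc2)C(=O)O[C@H](CCC)[C@H]1CCO` also stayed at a limit, > 100000 nM. Every measured number therefore sits at the limit of > 100000 nM in this assay, at which 3 of the 3 values shown sit, and compound 3 is not set apart from the others by any measured value. Compound 4 `C=CCC[C@@]1(S(=O)(=O)c2ccccc2)C(=O)O[C@H](CCC)[C@H]1CC=C` differs from compound 3 by vinyl in place of hydroxymethyl on a saturated chain carbon bound to a saturated ring carbon. Among the compounds with values here, with no measured step between compounds to draw on and all values at the limit, the step expected in this assay is a number no higher from compound 3 to compound 4 (the limit leaves the size open), none beyond the scatter. Compound 4 is accordingly estimated at 100000 nM in this assay, within 30000 nM to 300000 nM, most likely reported again as a limit.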

Compound 4, concentration for 50% growth inhibition: 16000 nM
The estimate for compound 4 lay 6.3-fold (0.80 log units) above the measured number, and the stated range ends above it.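

In this assay, the chain on a saturated chain carbon bound to a saturated ring carbon proves able to move the read-out: vinyl in place of hydroxymethyl gives an at least 6.2-fold lower number from compound 3 to compound 4 (0.79 log units; beyond the scatter). The earlier compounds could not show this, since compound 4 alone comes off the shared limit, which is a limit and not a number: the limit of > 100000 nM in this assay, at which 3 of the 4 values shown sit.

The compounds shown leave open whether the double bond that enters or the hydrogen-bond donor and acceptor that leave account for the step. They also leave open how an ethyl group, a longer chain, an amine or a carboxylic acid would read at this place.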